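Swapping a Pyridine for a Thiophene on a Weak Series

A few compounds are considered here, and "the series" means these few. Any claim that something is new, unique, unknown or untested is made for them only; others in the source may bear on it.

Measured compounds:
compound 1 `C/C(=N/N=C1\SCC(=O)N1Cc1ccccc1[N+](=O)[O-])c1cccs1` 2250000 nM
compound 2 `C/C(=N\N=C1/SCC(=O)N1Cc1cccc(Cl)c1)c1ccccn1` 1400000 nM
compound 3 `O=C1CS/C(=N\N=C2CCCC2)N1Cc1ccccc1F` 2370000 nM

All three were tested in a physicochemical assay, with a stated time of 30 min; a lower number here means that less compound is needed, a higher number that more compound is needed for the effect. Compound 2 gives the lowest of the three numbers, yet compound 1 and compound 3 both sit within the usual scatter of it, so no ordering among them can be claimed. Compound 4 `C/C(=N\N=C1/SCC(=O)N1Cc1cccc(Cl)c1)c1cccs1` differs from compound 2 in one place: thiophen-2-yl in place of pyridin-2-yl on a carbon with a double bond to nitrogen. Compound 1 already carries the thiophen-2-yl group on a different benzyl arm and gives 2250000 nM, a number within the scatter of compound 2. No change beyond the scatter is therefore expected in this assay for the step of a 1.3-fold higher number from compound 2 to compound 4 (0.11 log units; within the scatter). Compound 4 is expected to give about 1800000 nM, with a likely range from 700000 nM to 4500000 nM.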

Compound 4, half-maximal effective concentration: 1590000 nM
For compound 4 the middle estimate is 1.1-fold (0.05 log units) above the measured one; the range from low to high includes it.
By their numbers in this assay, from the lowest: compounds 2, 4, 1 and 3 (each within the scatter of the next).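

In this assay, among these compounds, thiophen-2-yl in place of pyridin-2-yl on a carbon with a double bond to nitrogen gives a 1.1-fold higher number from compound 2 to compound 4 (0.06 log units; within the scatter), the first comparison in which only this group differs. A six-membered and a five-membered aromatic ring, each with one hetero atom, therefore cannot be told apart at this position in this assay. No measurement shown explains this result. Still open, on these data alone, is whether a phenyl ring, a longer chain or a group carrying an amine at this position would give a number beyond the scatter.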